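The compounds below may be only part of what the source reports. "The series", "measured", "known", "first", "only" and "open" are said of these compounds alone.

Measured compounds in a functional assay on CNE-2 cells (Homo sapiens) for cytotoxicity, read by MTT assay, with a stated time of 72 h; a lower number here means a stronger inhibitor, a higher number a weaker inhibitor:
- compound 1, `O=C(NC(=S)NNc1ncnc2ccccc12)c1ccccc1F`, gives 4610 nM
- compound 2, `COc1cc2ncnc(NNC(=S)NC(=O)c3ccc(C)cc3)c2cc1OC`, gives 33300 nM
- compound 3, `O=C(NC(=S)NNc1ncnc2ccccc12)c1ccccc1`, gives 1490 nM

Compound 3 holds the lowest number of the three in this assay. Its nearest neighbour is compound 1, which differs only in a fluoro on the benzoyl ring, and the step from compound 1 to compound 3 is a 3.1-fold lower number from compound 1 to compound 3 (0.49 log units; beyond the scatter). Among the compounds with values here, compound 2, with a different core and a methyl on the benzoyl ring, stands much further away; no single-change step connects it to compound 3, so its number only shows that the series spans a wide range.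

Compound 4, `O=C(NC(=S)NNc1ncnc2ccccc12)c1cccc(Cl)c1`, is the next single change from compound 3: chloro in place of hydrogen on an aromatic carbon, on an aromatic carbon of the benzoyl ring, meta to a large group. Within the data shown here, the only measured step that bears on it is the one from compound 1 to compound 3, in which removing a halogen from the same ring gave a modest lowering. That halogen sat at a different position and was a fluoro, so it is an imperfect guide. On that basis, a modest rise in this assay is expected for compound 4, with the direction not secure, and the step from compound 3 to compound 4 is estimated at a 1.7-fold higher number from compound 3 to compound 4 (0.22 log units; within the scatter). Compound 4 is therefore expected at 2500 nM, within the range 800 nM to 8000 nM.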

Compound 4, half-maximal inhibitory concentration: 2920 nM
Beside the measured number, compound 4's estimate is 1.2-fold (0.07 log units) below it; low and high end bracket the measured number.
By their numbers in this assay, from the lowest: compounds 3, 4 and 1 (each within the scatter of the next, the first and the last beyond it); then compound 2.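

In this assay, within the data shown here, chloro in place of hydrogen on an aromatic carbon, meta to a large group, gives the first reading at this place on the ring, and a 2.0-fold higher number from compound 3 to compound 4 (0.29 log units; within the scatter) shows that phenyl and 3-chlorophenyl cannot be told apart here. The change from 2-fluorophenyl to 3-chlorophenyl, a 1.6-fold lower number from compound 1 to compound 4 (0.20 log units; within the scatter), is also within the scatter, and since it alters both the halogen and its place, it cannot be split into a contribution from either; compound 4 therefore sits within the scatter of compound 3 and of compound 1, although those two stay apart by a 3.1-fold lower number from compound 1 to compound 3 (0.49 log units; beyond the scatter). No supporting evidence bears on these readings.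

Open, going by these compounds, is whether a methoxy, a trifluoromethyl or an amine at this same place would move the number beyond the scatter, and whether chloro on other carbons of the ring would read as 3-chlorophenyl does. Among these compounds, also open is whether any of these steps carries over to the core of compound 2, which no single-change step links to compound 3 or compound 4.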